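Urea series: benzyloxy in place of 4-methylpiperidinyl

The source may hold more compounds than are shown below. What is called first, only, known or untested is meant among the compounds shown, and "the series" means these compounds.

Measured compounds:
compound 1 `CC1CCN(c2nc(C(F)(F)F)ccc2CNC(=O)Nc2cccc3c(=O)[nH]ccc23)CC1` — 9.59 nM
compound 2 `CC1CCN(c2nc(C(F)(F)F)ccc2CNC(=O)Nc2cccc3ccc(=O)[nH]c23)CC1` — "not active" (no number reported)
compound 3 `CC1CCN(c2nc(C(F)(F)F)ccc2CNC(=O)Nc2ccc3ccc(=O)[nH]c3c2)CC1` — "not active" (no number reported)

Three ureas share the same left-hand part and differ in the arrangement of the bicyclic lactam on the right. For the measured compounds named here, in an assay on CHO cells for agonist activity at transient receptor potential cation channel subfamily V member 1 (Homo sapiens) (a lower number here means that less compound is needed, a higher number that more compound is needed for the effect), compound 1 gives 9.59 nM and is the only compound of the three with a number. Going by the values given here, compound 2 was recorded as "not active" (no number reported) and compound 3 as "not active" (no number reported); for neither is a number given, so no step can be stated between them and compound 1, only that the bicyclic lactam arrangement of compound 1 is the one that carries measurable activity here.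

Compound 4 `O=C(NCc1ccc(C(F)(F)F)nc1OCc1ccccc1)Nc1cccc2c(=O)[nH]ccc12` keeps that arrangement and changes the left-hand part instead: benzyloxy in place of 4-methylpiperidin-1-yl on an aromatic carbon, in words benzyloxy in place of 4-methylpiperidin-1-yl on an aromatic carbon. Among the compounds with values here, no measured pair tells the size of such a change in this assay. Because compound 1 gives 9.59 nM and the right-hand part is unchanged, activity is expected to be kept, but with some loss that may lie beyond the scatter. The expected step is a 3.1-fold higher number from compound 1 to compound 4 (0.50 log units; beyond the scatter). Compound 4 is estimated at 30 nM, with a range from 5 nM to 200 nM.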

Compound 4, half-maximal effective concentration: 78.6 nM
Compound 4: middle estimate off by 2.6-fold (0.42 log units), on the low side, and the stated range covers the measured number.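

In this assay, the position next to the ring nitrogen accepts benzyloxy in place of 4-methylpiperidin-1-yl with a measurable result, compound 4 giving 78.6 nM, but the change costs an 8.2-fold higher number from compound 1 to compound 4 (0.91 log units; beyond the scatter). This gives the series its first numerical step and shows that the left-hand part, and not only the arrangement of the bicyclic lactam, shifts the number beyond the scatter; the swap exchanges a six-membered non-aromatic ring with 1 hetero atom for a six-membered aromatic ring of carbon only, and keeps activity in the same right-hand setting. Nothing available explains the size of this step.

This single swap alters both the ring and the way it is attached, so the two contributions remain inseparable; a benzylamino or cyclohexyloxy group at this position would be needed to tell them apart. Also open, from the compounds shown here alone, is whether a smaller group such as methoxy or a plain piperidin-1-yl ring would stay closer to compound 1, and whether benzyloxy behaves the same way with the other lactam arrangements, which offer no number to compare.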